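Bromo on the benzoyl ring: compound 1 to compound 4

This account rests on a few compounds, and the source may have more. Where it says the series, first, only, none or still open, it means among the compounds named here.

Measured in a functional assay on A549 cells (Homo sapiens) for inhibition, read by MTT assay, with a stated time of 24 h; a lower number here means a stronger inhibitor of growth, a higher number a weaker inhibitor of growth:
compound 1 `Cn1cc(-c2nc3ccccc3n2C(=O)c2ccccc2)c2ccccc21`: 19600 nM
compound 2 `COc1ccccc1C(=O)n1c(-c2cn(C)c3ccccc23)nc2ccccc21`: 12300 nM
compound 3 `COc1ccc(C(=O)n2c(-c3cn(C)c4ccccc34)nc3ccccc32)cc1OC`: 3100 nM

Compound 1 stands highest of the three numbers. Its nearest neighbour is compound 2, a 1.6-fold lower number from compound 1 to compound 2 (0.20 log units; within the scatter), a step within the scatter. The furthest is compound 3, a 6.3-fold lower number from compound 1 to compound 3 (0.80 log units; beyond the scatter), a modest step beyond the scatter; the related step of a 4.0-fold lower number from compound 2 to compound 3 (0.60 log units; beyond the scatter) also lies beyond the scatter.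

Compound 4 `Cn1cc(-c2nc3ccccc3n2C(=O)c2cccc(Br)c2)c2ccccc21` differs from compound 1 by bromo in place of hydrogen on an aromatic carbon. Among the compounds with values here, no bromo compound has yet been measured. Within the data shown here, the steps that bear on the change are both substitutions on the benzoyl ring of compound 1: the single methoxy gave a 1.6-fold lower number from compound 1 to compound 2 (0.20 log units; within the scatter), within the scatter, while only the two-methoxy pattern gave a 6.3-fold lower number from compound 1 to compound 3 (0.80 log units; beyond the scatter). A single substituent is therefore expected to move the number little in this assay, if at all, and in the lower direction if anything. The estimate for compound 4 is 12000 nM, with a range of 5000 nM to 30000 nM, which means an expected step of a 1.6-fold lower number from compound 1 to compound 4 (0.21 log units; within the scatter).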

Compound 4, concentration for 50% growth inhibition: 34200 nM
Compound 4: middle estimate off by 2.9-fold (0.45 log units), on the low side; the whole stated range lies below it.
By their numbers in this assay, from the lowest: compound 3; then compounds 2, 1 and 4 (each within the scatter of the next, the first and the last beyond it).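

Bromo in place of hydrogen on the benzoyl ring, meta to a large group, does not separate compound 4 from the unsubstituted parent: a 1.7-fold higher number from compound 1 to compound 4 (0.24 log units; within the scatter). Within the data shown here, this is the first non-methoxy substituent on this ring, and the lower numbers seen so far do not extend to it: a 2.8-fold higher number from compound 2 to compound 4 (0.44 log units; beyond the scatter), and an 11-fold higher number from compound 3 to compound 4 (1.04 log units; beyond the scatter), so the choice of group on the carbonyl carbon matters most between 3-bromophenyl and 3,4-dimethoxyphenyl. No measurement at hand accounts for these steps.

Compound 2 and compound 4 differ in both the group and its place on the ring, so a single methoxy at the bromo position remains the open comparison. Also open, on these data alone, is how an amine, a carboxylic acid or a longer alkoxy chain would read at that place.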